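A few compounds are considered here, and "the series" means these few. Any claim that something is new, unique, unknown or untested is made for them only; others in the source may bear on it.

Compound 2 `CCCN(CC[C@H](N)C(=O)O)C[C@H]1O[C@@H](n2cnc3c(N)ncnc32)[C@H](O)[C@@H]1O` carries a propyl group on the amine nitrogen of the shared core; in an assay for inhibition of tRNA (cytosine(38)-C(5))-methyltransferase (Homo sapiens), with a stated time of 5 min, tested at 100 uM (a lower number here means less inhibition, a higher number more inhibition at the concentration tested (going by the name of the read-out)), compound 2 has no result reported, so it has no single number to stand on. Its neighbours do: compound 1 `CN(CC[C@H](N)C(=O)O)C[C@H]1O[C@@H](n2cnc3c(N)ncnc32)[C@H](O)[C@@H]1O` gives 30.3% in this assay, and compound 3 `C=CCN(CC[C@H](N)C(=O)O)C[C@H]1O[C@@H](n2cnc3c(N)ncnc32)[C@H](O)[C@@H]1O` gives 53.9%. Compound 4 `C#CCCN(CC[C@H](N)C(=O)O)C[C@H]1O[C@@H](n2cnc3c(N)ncnc32)[C@H](O)[C@@H]1O` differs from compound 2 by ethynyl in place of methyl on a saturated chain carbon, two bonds along the chain from an amine nitrogen. For the measured compounds named here, the one measured step that bears on this, a number 23.6 percentage points higher from compound 1 to compound 3 (beyond the scatter), also introduced unsaturation on the chain at the amine nitrogen and gave a modest rise. On these data alone, a rise of similar size is therefore expected here, though the starting point of compound 2 is unknown. Compound 4 is estimated to give 45% in this assay, within a range of 20% to 70%.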

Compound 4, a percentage reported as inhibition, at one concentration (the size of the read-out at that concentration, not a potency): 30.2%
Compound 4: middle estimate off by 14.8 percentage points, on the high side; measured number inside the range.
By their numbers in this assay, from the lowest: compounds 4 and 1 (each within the scatter of the next); then compound 3.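

In this assay, the change from the vinyl-ended chain to the ethynyl-ended chain gives a number 23.7 percentage points lower from compound 3 to compound 4 (beyond the scatter), so unsaturation on this chain does not in itself bring a higher number. Set against the core with only a methyl group on the nitrogen, the but-3-yn-1-yl chain gives a number 0.1 percentage points lower from compound 1 to compound 4 (within the scatter), which leaves compound 3 as the only one of the three that stands out. Nothing measured here explains this difference. The compounds shown leave open how a chain ending in an amine or a carboxylic acid would behave, and whether a longer chain ending in vinyl would keep the higher number.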